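Thiophene amide series: cytotoxicity notes before an aryl swap

The source may report more compounds than this note shows. Statements on the series, on what has been measured and on what is new or still open speak of the compounds shown alone.

Measured compounds:
- compound 1 `O=C(Nc1ncc(Cc2ccc(Cl)cc2)s1)c1cccs1` — > 50000 nM
- compound 2 `O=C(Nc1ncc(C(Oc2ccc3cc(Br)ccc3c2)c2ccc(Cl)cc2)s1)c1cccs1` — "not toxic" (no number reported)
- compound 3 `COc1ccc(COC(c2ccccc2)c2cnc(NC(=O)c3cccs3)s2)cc1` — "not toxic" (no number reported)

In an ADME assay on HepG2 2.2.15 cells (Homo sapiens) for cytotoxicity (on this read-out lower numbers stand for higher toxicity in this test and higher numbers for lower toxicity in this test), compound 1 gives > 50000 nM; this is a limit of the assay and not a number. In this assay compound 2 gives "not toxic" (no number reported), an entry without a number. In this assay compound 3 likewise gives "not toxic" (no number reported), again without a number. Compound 2 therefore stands without a single number of its own; of the two other readings, one sits at the limit of > 50000 nM in this assay, at which 1 of the 3 values shown sits, and one is also given only as a word. All three readings point the same way, towards low toxicity, and no ordering among them can be drawn.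

Compound 4 `O=C(Nc1ncc(C(Oc2ccc3cc(Br)ccc3c2)c2ccc(Cl)cc2)s1)c1ccccc1` is the next compound to be run in this assay. It differs from compound 2 in one place: phenyl in place of thiophen-2-yl on a carbonyl carbon. Going by the values given here, no measured step between two compounds exists in this set, so the size of the change cannot be read from a pair. With the three readings all at the non-toxic end, the expectation for this assay is no shift beyond the scatter in either direction.

Compound 4 is expected to give an estimated 60000 nM, with a range of 20000 nM to 150000 nM, most likely reported as a limit only.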

Compound 4, half-maximal cytotoxic concentration: "not toxic" (no number reported)
For compound 4 the study gives words and no number, so the estimate cannot be set against anything.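

In this assay compound 2 and compound 4 are both reported only in words, as not toxic, so no step can be read for thiophen-2-yl to phenyl. Compound 1 carries a limit and not a number: the limit of > 50000 nM in this assay, at which 1 of the 4 values shown sits. The compounds shown leave open whether this swap changes cytotoxicity at all when expressed as a number.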